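Amide variation on the shared core: expectation for compound 4

The source may hold more compounds than are shown below. What is called first, only, known or untested is meant among the compounds shown, and "the series" means these compounds.

The three measured compounds share one core and differ only in the group on the amide carbonyl carbon. Compound 1 `CCC(=O)N(C)c1ccc2[nH]c(-c3n[nH]c4ccccc34)cc2n1` carries an ethyl there, and in a functional assay on HCT-116 cells (Homo sapiens) for antiproliferative activity, read by MTT assay, with a stated time of 72 h (a higher number here means a weaker inhibitor, a lower number a stronger inhibitor), compound 1 gives 10800 nM. Compound 2 `CN(C(=O)C(C)(C)C)c1ccc2[nH]c(-c3n[nH]c4ccccc34)cc2n1` carries a tert-butyl, and in this assay compound 2 gives 18000 nM. Compound 3 `CN(C(=O)c1ccccc1)c1ccc2[nH]c(-c3n[nH]c4ccccc34)cc2n1` carries a phenyl, and in this assay compound 3 gives 10600 nM. Compound 3 has the lowest of the three numbers, yet a 1.0-fold lower number from compound 1 to compound 3 (0.01 log units; within the scatter) and a 1.7-fold lower number from compound 2 to compound 3 (0.23 log units; within the scatter) are both within the scatter, so no ordering among the three can be claimed; a 1.7-fold higher number from compound 1 to compound 2 (0.22 log units; within the scatter) is likewise within the scatter.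

Compound 4 `CN(C(=O)CCc1ccccc1)c1ccc2[nH]c(-c3n[nH]c4ccccc34)cc2n1` is not yet measured. It differs from compound 3 by phenethyl in place of phenyl on a carbonyl carbon. For the measured compounds named here, the steps that bear on this are the three exchanges of the group on the carbonyl carbon already recorded, none of which moved this assay beyond the scatter. On that basis the expected step is a 1.0-fold higher number from compound 3 to compound 4 (0.02 log units; within the scatter), which is no larger than the scatter and has no favoured direction. Compound 4 is therefore estimated at 11000 nM in this assay, within a range from 5000 nM to 25000 nM.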

Compound 4, half-maximal inhibitory concentration: 11200 nM
Compound 4: the middle estimate sits 1.0-fold (0.01 log units) below what was measured; low and high end bracket the measured number.
By their numbers in this assay, from the lowest: compounds 3, 1, 4 and 2 (each within the scatter of the next).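

In this assay, phenethyl, with 8 heavy atoms against 6 for phenyl, gives a 1.1-fold higher number from compound 3 to compound 4 (0.02 log units; within the scatter) and so extends the group on a carbonyl carbon whose other neighbour is an amide-type nitrogen without leaving the scatter. The other two steps to compound 4 read the same way: a 1.6-fold lower number from compound 2 to compound 4 (0.21 log units; within the scatter) and, for phenyl in place of hydrogen on a saturated chain carbon, two bonds along the chain from a carbonyl carbon, a 1.0-fold higher number from compound 1 to compound 4 (0.02 log units; within the scatter). Ethyl, tert-butyl, phenyl and phenethyl therefore form a set of four groups at this position with every listed step within the scatter, and no information on hand accounts for this.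

From the compounds shown here alone, whether an amine, a carboxylic acid or a longer chain ending in phenyl on the carbonyl carbon would give a step beyond the scatter remains open. Going by these compounds, the shared core and the methyl on the amide-type nitrogen are the same in all four compounds, so what changes at those parts would do in this assay is also open.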